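The source may report more compounds than this note shows. Statements on the series, on what has been measured and on what is new or still open speak of the compounds shown alone.

Compound 1 `COc1cc(C)cc(-c2c(-c3ccnc(-c4ccc(N(C)C)cc4)c3)cnn2CC#N)c1`: 290 nM
Compound 2 `COc1cc(C)cc(-c2nn(CC#N)cc2-c2ccnc(-c3ccc(N(C)C)cc3)c2)c1`: 696 nM

Among the compounds with values here, of the two numbers measured so far in a functional assay on EKVX cells (Homo sapiens) for inhibition, read by sulforhodamine B assay, with a stated time of 48 h (a lower number here means a stronger inhibitor of growth, a higher number a weaker inhibitor of growth), compound 2 gives the higher one; its gap to compound 1 lies beyond the usual scatter. Compound 3 `Cc1cc(O)cc(-c2nn(CC#N)cc2-c2ccnc(-c3ccc(N(C)C)cc3)c2)c1` has not yet been measured. It differs from compound 2 by hydrogen in place of methyl on an oxygen on an aromatic ring, which read one bond further out is methoxy to hydroxy. Within the data shown here, no measured pair shows this change, so its size is unknown from the data; for compound 3 a step of no more than the scatter is expected, in no fixed direction, a 1.1-fold higher number from compound 2 to compound 3 (0.06 log units; within the scatter). The estimate for compound 3 is 800 nM, with a range from 300 nM to 2500 nM.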

Compound 3, concentration for 50% growth inhibition: 3920 nM
The estimate for compound 3 lay 4.9-fold (0.69 log units) below the measured number; measured number outside the range, above it.
By their numbers in this assay, from the lowest: compound 1; then compound 2; then compound 3.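

In this assay, within the data shown here, the change from 3-methoxy-5-methylphenyl to 3-hydroxy-5-methylphenyl gives a 5.6-fold higher number from compound 2 to compound 3 (0.75 log units; beyond the scatter) and is the first single-place step. This position is therefore sensitive to the methyl on the oxygen, and the hydroxy compound is the weaker inhibitor of growth of this pair. Nothing measured here explains the step. Going by these compounds, whether ethoxy or an amine at this place would hold growth inhibition stays open. Also open, on these data alone, is whether the same change gives a similar step on the arrangement of compound 1.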